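Swapping a Methyl for a Dichlorophenyl on the Ring Nitrogen

A few compounds are considered here, and "the series" means these few. Any claim that something is new, unique, unknown or untested is made for them only; others in the source may bear on it.

Three measured compounds share one core and differ only in the group carried on an amine nitrogen in a ring. Compound 1 `N#Cc1ccc(Nc2nc(Oc3ccnc4ccccc34)nc(N3CCN(c4ccccc4Cl)CC3)n2)cc1C(F)(F)F` carries a 2-chlorophenyl there, and in a functional assay on DU-145 cells (Homo sapiens) for cytotoxicity, read by sulforhodamine B assay, with a stated time of 48 h (on this read-out lower numbers stand for stronger inhibition of growth and higher numbers for weaker inhibition of growth), compound 1 gives 92600 nM. Compound 2 `CN1CCN(c2nc(Nc3ccc(C#N)c(C(F)(F)F)c3)nc(Oc3ccnc4ccccc34)n2)CC1` carries a methyl in that place, and in this assay compound 2 gives 51200 nM. The step of a 1.8-fold lower number from compound 1 to compound 2 (0.26 log units; within the scatter) is therefore small. Compound 3 `N#Cc1ccc(Nc2nc(Oc3ccnc4ccccc34)nc(N3CCN(C(c4ccccc4)c4ccccc4)CC3)n2)cc1C(F)(F)F` carries a diphenylmethyl, and in this assay compound 3 reaches only the limit of the assay, > 100000 nM. That is the limit of > 100000 nM in this assay, at which 1 of the 3 values shown sits. Among the numbers shown, compound 2 has the lowest, but compound 1 lies within the scatter of it, so no order between them can be claimed.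

Compound 4 `N#Cc1ccc(Nc2nc(Oc3ccnc4ccccc34)nc(N3CCN(c4cccc(Cl)c4Cl)CC3)n2)cc1C(F)(F)F` differs from compound 2 in one place: 2,3-dichlorophenyl in place of methyl on an amine nitrogen in a ring. Within the data shown here, the only measured step that speaks to this kind of change is a 1.8-fold lower number from compound 1 to compound 2 (0.26 log units; within the scatter), where an aryl group stood against a methyl on the same nitrogen and the numbers stayed within the scatter. An aryl group in this position is therefore expected to leave the read-out in this assay near where compound 1 sits, with a step of a 1.6-fold higher number from compound 2 to compound 4 (0.19 log units; within the scatter) that may stay within the scatter or rise a little. Compound 4 is estimated to give 80000 nM, expected between 30000 nM and 160000 nM.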

Compound 4, concentration for 50% growth inhibition: > 100000 nM
Compound 4: only a limit was reported; the forecaster's own chance of this, stated with the estimate: 25%; at least 1.2-fold (0.09 log units) between middle value and limit.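

With 2,3-dichlorophenyl on the ring nitrogen, compound 4 joins the compounds that give no number in this assay, only a limit of the assay: the limit of > 100000 nM in this assay, at which 2 of the 4 values shown sit. The step from the methyl reads an at least 1.9-fold higher number from compound 2 to compound 4 (0.29 log units; that floor lies within the scatter), and the added chloro on the aromatic ring reads an at least 1.0-fold higher number from compound 1 to compound 4 (0.03 log units; that floor lies within the scatter); each of these is only a floor, and the true step could be larger or could stay within the scatter. What compound 4 adds is a second large group on this nitrogen, after the diphenylmethyl of compound 3, that ends at the limit, so none of the groups shown here with an aromatic ring has yet given a value clearly beyond the scatter of the methyl in compound 2.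

The compounds shown leave open how far compound 4 truly lies from compound 1 and compound 2, as a limit cannot settle that. They also leave open whether a plain hydrogen on this nitrogen, a short chain ending in an amine, or a carboxylic acid would move the number clearly away from that of compound 2 in either direction.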